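Expected small step from 3,4-dichlorobenzyl to 2-chloro-4-fluorobenzyl

A few compounds are considered here, and "the series" means these few. Any claim that something is new, unique, unknown or untested is made for them only; others in the source may bear on it.

Compound 1 `OC[C@H]1O[C@@H](n2cnc3c(NCc4ccccc4Br)ncnc32)[C@H](O)[C@@H]1O` - > 166000 nM (a limit)
Compound 2 `OC[C@H]1O[C@@H](n2cnc3c(NCc4cccc(Br)c4)ncnc32)[C@H](O)[C@@H]1O` - > 166000 nM (a limit)
Compound 3 `OC[C@H]1O[C@@H](n2cnc3c(NCc4ccc(Cl)c(Cl)c4)ncnc32)[C@H](O)[C@@H]1O` - 88800 nM (a number)

Within the data shown here, in a functional assay on MCF cells (Homo sapiens) for antiproliferative activity, with a stated time of 72 h (on this read-out lower numbers stand for stronger inhibition and higher numbers for weaker inhibition), compound 3 gives the only true number at 88800 nM and stands alone in that respect. Compounds 1 and 2 both rest at the limit of > 166000 nM in this assay, at which 2 of the 3 values shown sit, and give no number.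

Compound 4 `OC[C@H]1O[C@@H](n2cnc3c(NCc4ccc(F)cc4Cl)ncnc32)[C@H](O)[C@@H]1O` carries this change on the shared core: 2-chloro-4-fluorophenyl in place of 3,4-dichlorophenyl on a saturated chain carbon bound to a nitrogen on an aromatic ring and nothing else differs. Among the measured compounds shown here, the steps that bear on it are an at least 1.8-fold lower number from compound 1 to compound 3 (0.27 log units; that floor lies within the scatter) and an at least 1.8-fold lower number from compound 2 to compound 3 (0.27 log units; that floor lies within the scatter) and both start from a limit, so neither gives a firm size. No step beyond the scatter is therefore expected in this assay and the estimated step is a 1.3-fold higher number from compound 3 to compound 4 (0.11 log units; within the scatter) for now. For compound 4 the estimated value is 115000 nM (expected range 45000 nM to 250000 nM).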

Compound 4, half-maximal inhibitory concentration: > 166000 nM
Compound 4 was reported as a limit; the forecaster's own chance of this, stated with the estimate: 40%; at least 1.4-fold (0.15 log units) between middle value and limit.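

In this assay, as far as these compounds go, the change from 3,4-dichlorophenyl to 2-chloro-4-fluorophenyl at this place gives an at least 1.8-fold higher number from compound 3 to compound 4 (0.27 log units; that floor lies within the scatter), so only a floor is known and the true size stays open. Among these compounds, compound 4 gives a limit and no number, leaving compound 3 as the only compound here with a true value: the limit of > 166000 nM in this assay, at which 3 of the 4 values shown sit. The steps from compound 1 and compound 2 to compound 4 cannot be read, since both ends are limits.

From the compounds shown here alone, it remains open whether a methoxy group or an amine on this phenyl ring, or a longer chain to the ring, would give a measurable value.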